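This account rests on a few compounds, and the source may have more. Where it says the series, first, only, none or still open, it means among the compounds named here.

Compound 1 `CCC1C(=O)N(C)c2cnc(-n3ccc4cc(C(=O)NC)ccc43)nc2N1c1ccn(C)n1`: 35400 nM
Compound 2 `CCCNC(=O)c1ccc2c(ccn2-c2ncc3c(n2)N(c2ccn(C)n2)C(CC)C(=O)N3C)c1`: 6420 nM

In a functional assay on MCF7 cells (Homo sapiens) for antiproliferative activity, read by CCK-8 assay, with a stated time of 72 h (a higher number here means a weaker inhibitor of growth, a lower number a stronger inhibitor of growth), compound 2 gives 6420 nM, the lower of the two numbers, which makes it the stronger inhibitor of growth so far. Compound 3 `CCCCNC(=O)c1ccc2c(ccn2-c2ncc3c(n2)N(c2ccn(C)n2)C(CC)C(=O)N3C)c1` carries one change: methyl in place of hydrogen on a saturated chain carbon, three bonds along the chain from an amide-type nitrogen. This is methyl in place of hydrogen on a saturated chain carbon, three bonds along the chain from an amide-type nitrogen, and it turns propyl into butyl.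

Among the compounds with values here, only one measured step bears on this: a 5.5-fold lower number from compound 1 to compound 2 (0.74 log units; beyond the scatter), where ethyl replaced hydrogen on the chain. That step was modest, though beyond the scatter. A single step cannot show whether the trend continues. The new addition is only methyl, so a smaller step in the same direction is expected, possibly one that stays within the scatter. The expected change is a 1.5-fold lower number from compound 2 to compound 3 (0.17 log units; within the scatter). For compound 3 the estimate is 4300 nM, with an expected range from 1700 nM to 10000 nM.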

Compound 3, concentration for 50% growth inhibition: 8990 nM
The estimate for compound 3 lay 2.1-fold (0.32 log units) below the measured number; the measured number falls inside the stated range.
By their numbers in this assay, from the lowest: compounds 2 and 3 (each within the scatter of the next); then compound 1.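

In this assay, extending the chain from propyl to butyl gives a 1.4-fold higher number from compound 2 to compound 3 (0.15 log units; within the scatter) and so leaves the two compounds indistinguishable: at this position, the added methyl makes no measurable difference. The gain from the longer chain nevertheless persists, as the overall change of propyl in place of hydrogen gives a 3.9-fold lower number from compound 1 to compound 3 (0.60 log units; beyond the scatter) on the same chain. The first lengthening therefore produced a step beyond the scatter, whereas this further methyl did not, and nothing available here explains that contrast.

Only three chain lengths are shown, so they cannot tell whether a longer chain such as hexyl would stay at this level or move away from it. On these data alone, it also remains open how a chain ending in an amine or a carboxylic acid would behave at this position.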